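Same Aryl Swap on Two Cores: Expecting Compound 4

This account rests on a few compounds, and the source may have more. Where it says the series, first, only, none or still open, it means among the compounds named here.

Compound 1 `CC(=O)OC[C@H]1O[C@H](OC[C@@H](Cn2cc(CN(c3nc(-c4ccc(F)cc4)no3)C3CCCCC3)nn2)OC(C)=O)C=C[C@@H]1OC(C)=O` and compound 2 `CC(=O)OC[C@H]1O[C@H](OC[C@@H](Cn2cc(CN(c3nc(-c4cccc(C)c4)no3)C3CCCCC3)nn2)OC(C)=O)C=C[C@@H]1OC(C)=O` share one core, while compound 3 `C#CCN(c1nc(-c2ccc(F)cc2)no1)C1CCCCC1` and compound 4 `C#CCN(c1nc(-c2cccc(C)c2)no1)C1CCCCC1` share a smaller one; how the two cores differ is not broken down here. In an ADME assay on RAW264.7 cells (Mus musculus) for cytotoxicity, read by MTT assay, with a stated time of 48 h (on this read-out higher numbers stand for lower toxicity in this test and lower numbers for higher toxicity in this test), compound 1 gives 31.5 ug/mL and compound 2 gives 46.4 ug/mL. The change between them, (3-methylphenyl in place of 4-fluorophenyl on an aromatic carbon), made a step of a 1.5-fold higher number from compound 1 to compound 2 (0.17 log units; within the scatter). In this assay compound 3 gives 20.9 ug/mL, a number within the scatter of compound 1 but beyond it next to compound 2. Compound 4 carries the same change on the smaller core: 3-methylphenyl in place of 4-fluorophenyl on an aromatic carbon, at a place described in the same words as before, so it is the same change. Because the earlier step was a 1.5-fold higher number from compound 1 to compound 2 (0.17 log units; within the scatter), the step from compound 3 to compound 4 in this assay is expected to be of similar size, a 1.4-fold higher number from compound 3 to compound 4 (0.16 log units; within the scatter). Compound 4 is therefore estimated to give 30 ug/mL in this assay, most likely between 15 ug/mL and 60 ug/mL.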

Compound 4, half-maximal cytotoxic concentration: 25.9 ug/mL
Compound 4: middle estimate off by 1.2-fold (0.06 log units), on the high side; the measured number falls inside the stated range.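

On the smaller core, putting 3-methylphenyl in place of 4-fluorophenyl in this assay gave a 1.2-fold higher number from compound 3 to compound 4 (0.09 log units; within the scatter), a step too small to separate from repeat measurements. Set beside the same swap on the larger core, the change looks alike on both cores, and the two steps cannot be told apart: the same change on two cores in this assay, a 1.5-fold higher number (0.17 log units; within the scatter) from compound 1 to compound 2 and a 1.2-fold higher number (0.09 log units; within the scatter) from compound 3 to compound 4, 1.2-fold (0.08 log units) apart, within the scatter of two such steps This shows only that the swap had no readable effect on either core, so the agreement is between two small steps; it does not show that a larger effect would carry across, and one change on two cores makes no rule for the whole series.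

The compounds shown leave open what happens with a more different group on the phenyl ring, such as an amine or a carboxylic acid in place of the fluorine or the methyl. If such a group gave a step beyond the scatter, it would be a stronger test of whether a change carries from one core to the other.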